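Lipophilicity of an imidazoline series: an ethyl-to-thienyl exchange

The source may hold more compounds than are shown below. What is called first, only, known or untested is meant among the compounds shown, and "the series" means these compounds.

Compound 1 `CCN(C1=NCCN1)c1c(Br)cccc1Br`: -1.01
Compound 2 `CCCN(C1=NCCN1)c1c(Br)cccc1Br`: -0.55
Compound 3 `Brc1cccc(Br)c1N(CC1CCC1)C1=NCCN1`: -0.06

Of the compounds shown here, three sharing one core have been measured in a physicochemical assay for lipophilicity; on this read-out lower numbers stand for lower lipophilicity and higher numbers for higher lipophilicity. Compound 2 stands second highest of the three: the nearest is compound 1, and the step runs a number 0.46 log units higher from compound 1 to compound 2 (beyond the scatter); the furthest is compound 3, reached by a number 0.49 log units higher from compound 2 to compound 3 (beyond the scatter). Both steps lie beyond the scatter, and compound 1 to compound 3 gives a number 0.95 log units higher from compound 1 to compound 3 (beyond the scatter).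

The next compound, compound 4 `Brc1cccc(Br)c1N(Cc1cccs1)C1=NCCN1`, has not yet been measured in this assay. It differs from compound 2 as follows: thiophen-2-yl in place of ethyl on a saturated chain carbon bound to a nitrogen on an aromatic ring. The measured steps that bear on this change are those that add carbon on the same saturated chain carbon, a number 0.46 log units higher from compound 1 to compound 2 (beyond the scatter) and a number 0.49 log units higher from compound 2 to compound 3 (beyond the scatter), each a modest rise. The thiophen-2-yl group brings more heavy atoms than the cyclobutyl did, but also one hydrogen-bond acceptor, so a rise of a similar, modest size is expected. For compound 4 the expected step is a number 0.40 log units higher from compound 2 to compound 4 (beyond the scatter), upward and beyond the scatter. Compound 4 is therefore estimated at -0.15, within a range from -0.6 to 0.3.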

Compound 4, distribution coefficient: -0.1
For compound 4 the middle estimate is 0.05 log units below the measured one; low and high end bracket the measured number.
By their numbers in this assay, from the lowest: compound 1; then compound 2; then compounds 4 and 3 (each within the scatter of the next).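

In this assay, among these compounds, compound 4 is the first of the series to carry an aromatic ring on the saturated chain carbon bound to a nitrogen on an aromatic ring, and the exchange of ethyl for thiophen-2-yl gives a number 0.45 log units higher from compound 2 to compound 4 (beyond the scatter) as a modest rise. Set against the smallest group in the series, the same position gives a number 0.91 log units higher from compound 1 to compound 4 (beyond the scatter) and so spans nearly the full range seen so far, which shows that this position tolerates a sulfur-bearing aromatic ring without the upward run of the series being broken. The new comparison is with cyclobutyl: a number 0.04 log units lower from compound 3 to compound 4 (within the scatter) leaves these two compounds level on this read-out, so that the five-membered aromatic ring, with its sulfur and its hydrogen-bond acceptor, cannot be told apart here from the cyclobutyl group.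

Going by these compounds, whether a phenyl group, a furan-2-yl group or a longer chain at the same place would stay level with compounds 3 and 4 or move away from them remains open. No independent data are at hand to say why thiophen-2-yl and cyclobutyl end up level.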